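Thiadiazolyl to methylthiazolyl sulfide on the shared core

This account rests on a few compounds, and the source may have more. Where it says the series, first, only, none or still open, it means among the compounds named here.

Measured compounds in a functional assay on SMMC-7721 cells (Homo sapiens) for antiproliferative activity, read by MTT assay, with a stated time of 72 h; on this read-out lower numbers stand for stronger inhibition and higher numbers for weaker inhibition:
compound 1 `C#CCSc1nc(Sc2nc(C)c(C)s2)c(C#N)c(-c2cc(OC)c(OC)c(OC)c2)n1`, > 20000 nM (a limit of the assay)
compound 2 `C#CCSc1nc(Sc2nccs2)c(C#N)c(-c2ccc(Br)cc2)n1`, 3990 nM
compound 3 `C#CCSc1nc(Sc2nncs2)c(C#N)c(-c2cc(OC)c(OC)c(OC)c2)n1`, 4660 nM

Compound 3 gives the higher of the two numbers shown, and compound 2 sits within the scatter of it. Compound 1 reports only a limit of the assay (the limit of > 20000 nM in this assay, at which 1 of the 3 values shown sits).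

Compound 4 `C#CCSc1nc(Sc2nc(C)cs2)c(C#N)c(-c2cc(OC)c(OC)c(OC)c2)n1` differs from compound 3 by 4-methyl-1,3-thiazol-2-yl in place of 1,3,4-thiadiazol-2-yl on a sulfur. Among the measured compounds shown here, the one step that bears on this is an at least 4.2-fold lower number from compound 1 to compound 3 (0.63 log units; beyond the scatter), where replacing the ring bearing two methyl groups by the thiadiazolyl ring lowered the number beyond the scatter. The 4-methyl-1,3-thiazol-2-yl ring of compound 4 carries one methyl group, so a move back toward the number of compound 1 is expected, in this assay a step upward of about a 2.6-fold higher number from compound 3 to compound 4 (0.41 log units; beyond the scatter). Compound 4 is therefore estimated at 12000 nM, with a range from 5000 nM to 25000 nM, and a real chance that only a limit is returned.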

Compound 4, half-maximal inhibitory concentration: > 20000 nM
Compound 4 ended at the assay's limit; the forecaster's own chance of this, stated with the estimate: 30%; middle value at least 1.6-fold (0.22 log units) away from the limit.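

On this sulfur, 4-methyl-1,3-thiazol-2-yl in place of 1,3,4-thiadiazol-2-yl gives an at least 4.2-fold higher number from compound 3 to compound 4 (0.63 log units; beyond the scatter). Compound 4 gives > 20000 nM, a limit of the assay, so a single methyl group on the thiazole ring already goes with a value at that limit. The step from compound 1 to compound 4, hydrogen in place of methyl on an aromatic carbon, cannot be read: the limit of > 20000 nM in this assay, at which 2 of the 4 values shown sit.

Among the compounds shown here, whether the ring change or the methyl group carries the step stays open, since compound 2, the only thiazole without methyl groups, differs from compound 3 in more than one place. Going by these compounds, how an amine or a carboxylic acid on this ring would read also stays open.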